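The source may hold more compounds than are shown below. What is called first, only, known or untested is meant among the compounds shown, and "the series" means these compounds.

Of the compounds shown here, three of one series have been tested in an assay on cells for displacement of a labelled ligand from somatostatin receptor type 4 (Homo sapiens), with a stated time of 90 min; on this read-out higher numbers stand for weaker inhibition and lower numbers for stronger inhibition. Compound 1, `Clc1ccc(Cn2c(CCc3c[nH]cn3)nnc2Cc2c[nH]c3ccccc23)cc1Cl`, gives > 10000 nM, which is a limit of the assay and not a number. Compound 2, `Clc1ccc(Cn2c(Cc3c[nH]c4ccccc34)nnc2C2CCNCC2)cc1Cl`, likewise reaches only a limit, > 10000 nM. Compound 3, `c1ccc(Cn2c(Cc3c[nH]c4ccccc34)nnc2C2CCNCC2)cc1`, also stops at a limit, > 10000 nM. The steps a step that the two limits leave unreadable from compound 1 to compound 2 and a step that the two limits leave unreadable from compound 2 to compound 3 thus cannot be sized, since (the limit of > 10000 nM in this assay, at which 3 of the 3 values shown sit). Compound 4, `Clc1ccc(Cn2c(CCc3c[nH]c4ccccc34)nnc2C2CCNCC2)cc1Cl`, is not yet measured; it differs from compound 2 in that ((1H-indol-3-yl)methyl in place of 1H-indol-3-yl on a saturated chain carbon bound to an aromatic carbon). Within the data shown here, compound 2 stands at a limit, and no measured step bears on this change. The expectation is that compound 4 stays at that limit, the estimated step being a step that the limit leaves unreadable from compound 2 to compound 4. Compound 4 is therefore estimated at 20000 nM, within 5000 nM to 100000 nM.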

Compound 4, inhibition constant: > 10000 nM
Compound 4 ended at the assay's limit; the forecaster's own chance of this, stated with the estimate: 80%; the middle value lies beyond the limit too.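

Among these compounds, compound 2 and compound 4 both stop at a limit, so no step between them can be read: the limit of > 10000 nM in this assay, at which 4 of the 4 values shown sit. The compounds shown leave open whether any member of this series gives a value inside the assay's range.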